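The compounds below may be only part of what the source reports. "The series", "measured", "known", "first", "only" and "open" are said of these compounds alone.

Three related compounds already have numbers in a functional assay on MOLT-4 cells (Homo sapiens) for antiproliferative activity, with a stated time of 48 h; on this read-out lower numbers stand for stronger inhibition and higher numbers for weaker inhibition. Compound 3 `C=C(Br)C(=O)Nc1ccc(C(=O)/C=C/c2ccccc2)cc1` gives 500 nM, the lowest of the three. Compound 2 `C=C(Br)C(=O)Nc1ccc(/C=C/C(=O)c2ccc(OC)cc2)cc1` gives 1300 nM and compound 1 `C=C(Br)C(=O)Nc1ccc(/C=C/C(=O)c2ccc(I)cc2)cc1` gives 2800 nM, so compound 3 is the strongest inhibitor measured so far.

Compound 4 `C=C(Br)C(=O)Nc1ccc(C(=O)/C=C/c2ccc(OC)cc2)cc1` keeps all of compound 3 except for one change: methoxy in place of hydrogen on an aromatic carbon. Put simply, methoxy comes in place of hydrogen on an aromatic carbon, turning phenyl into 4-methoxyphenyl.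

Going by the values given here, no measured pair shows this exact swap. The closest evidence is a 2.2-fold lower number from compound 1 to compound 2 (0.33 log units; beyond the scatter), where methoxy replaces iodo. That step starts from iodo rather than hydrogen, and compounds 1 and 2 also differ from compound 3 elsewhere in their structures, so it gives only weak guidance on direction here.

With so little to go on, no step beyond the scatter is expected, and the estimated change is a 1.2-fold higher number from compound 3 to compound 4 (0.08 log units; within the scatter). The estimate leans slightly upward, since compound 2, which also carries a methoxy, stands at 1300 nM. For compound 4 the expected value is 600 nM, with an estimated range of 200 nM to 1800 nM.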

Compound 4, half-maximal inhibitory concentration: 610 nM
Estimate against measurement, compound 4: 1.0-fold (0.01 log units) below; the range from low to high includes it.
By their numbers in this assay, from the lowest: compounds 3 and 4 (each within the scatter of the next); then compound 2; then compound 1.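

Methoxy in place of hydrogen on this aromatic carbon, para to a large group, gives a 1.2-fold higher number from compound 3 to compound 4 (0.09 log units; within the scatter) in this assay, so phenyl and 4-methoxyphenyl cannot be told apart on this read-out. Going by these compounds alone, this is the first direct reading of that swap at this position: the earlier step, a 2.2-fold lower number from compound 1 to compound 2 (0.33 log units; beyond the scatter), began from iodo rather than hydrogen and sat on a core that differs from that of compound 3, whereas here a group of two heavy atoms with one hydrogen-bond acceptor enters without a shift beyond the scatter. No measurement shown here offers an explanation for this near absence of change.

The compounds shown leave open whether this position would respond in the same way to quite different groups, such as a hydroxyl, an amine, a carboxylic acid or a longer chain like butoxy. They also leave open whether a methoxy on another carbon of this ring, or a second methoxy alongside the first on the same ring, would stay as close to compound 3 as this one does.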